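From Phenyl to 4-Chlorophenyl on Compound 3

This account rests on a few compounds, and the source may have more. Where it says the series, first, only, none or still open, it means among the compounds named here.

In an ADME assay on HCT-116 cells (Homo sapiens) for cytotoxicity, read by CellTiter-Glo, with a stated time of 72 h (on this read-out lower numbers stand for stronger inhibition and higher numbers for weaker inhibition), compound 1 `CC1CCN(C2CCN(S(=O)(=O)c3ccccc3Br)CC2)CC1` gives > 5000 nM, which is a limit and not a number. Compound 2 `CC1CCN(C2CCN(S(=O)(=O)c3ccccc3-c3ccc(C(F)(F)F)cc3)CC2)CC1` gives > 5000 nM, also a limit. Compound 3 `CC1CCN(C2CCN(S(=O)(=O)c3ccccc3-c3ccccc3)CC2)CC1` gives > 5000 nM, again only a limit. All three therefore stand at one mark: the limit of > 5000 nM in this assay, at which 3 of the 3 values shown sit.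

Compound 4 `CC1CCN(C2CCN(S(=O)(=O)c3ccccc3-c3ccc(Cl)cc3)CC2)CC1` carries chloro in place of hydrogen on an aromatic carbon, para to a large group (chloro in place of hydrogen on an aromatic carbon). The closest comparison is compound 2, with its 4-(trifluoromethyl)phenyl, yet a step that the two limits leave unreadable from compound 2 to compound 3. The others, a step that the two limits leave unreadable from compound 1 to compound 2 and a step that the two limits leave unreadable from compound 1 to compound 3, give no size either. Nothing beyond the scatter is expected, so the estimated change is a step that the limit leaves unreadable from compound 3 to compound 4. For compound 4 the expected value is 7000 nM, with an estimated range of 3000 nM to 15000 nM.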

Compound 4, half-maximal inhibitory concentration: > 5000 nM
Compound 4: a limit, no number; the forecaster's own chance of this, stated with the estimate: 88%; the middle value is on the limit's open side.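

Compound 1, compound 2, compound 3 and compound 4 all give the same limit and no number, so no step among them can be read: the limit of > 5000 nM in this assay, at which 4 of the 4 values shown sit.

Going by these compounds, how far these four compounds truly differ in this assay stays open.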